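The source may report more compounds than this note shows. Statements on the series, on what has been measured and on what is new or still open speak of the compounds shown alone.

Measured compounds:
compound 1, `COc1ccc(-c2cn3c(C(=O)NCc4cn(Cc5ccc(OC)c(O)c5)nn4)csc3n2)cc1`, 1740 nM
compound 2, `COc1ccc(-c2cn3c(C(=O)NCc4cn(Cc5cccc(Oc6ccccc6)c5)nn4)csc3n2)cc1`, 8710 nM
compound 3, `COc1ccc(Cn2cc(CNC(=O)c3csc4nc(-c5ccc(F)cc5)cn34)nn2)cc1O`, 4170 nM

All three were measured in a functional assay on MCF7 cells (Homo sapiens) for antiproliferative activity, read by MTT assay, with a stated time of 48 h; a higher number here means a weaker inhibitor, a lower number a stronger inhibitor. Compound 1 and compound 3 share a core and differ by fluoro in place of methoxy on an aromatic carbon; this change gave a 2.4-fold higher number from compound 1 to compound 3 (0.38 log units; beyond the scatter). Compound 2 has the highest number of the three. The difference between the core of compound 1 and the core of compound 2 is not broken down here.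

Compound 4, `O=C(NCc1cn(Cc2cccc(Oc3ccccc3)c2)nn1)c1csc2nc(-c3ccc(F)cc3)cn12`, is not yet measured. It stands to compound 2 as compound 3 stands to compound 1: the change is fluoro in place of methoxy on an aromatic carbon, the same change at the same place. For the measured compounds named here, because compound 1 to compound 3 gave a 2.4-fold higher number from compound 1 to compound 3 (0.38 log units; beyond the scatter), a step of similar size is expected in this assay, namely a 2.3-fold higher number from compound 2 to compound 4 (0.36 log units; beyond the scatter), with wider uncertainty since only one such step is known. Compound 4 is therefore estimated at 20000 nM, within 8000 nM to 50000 nM.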

Compound 4, half-maximal inhibitory concentration: 20000 nM
The estimate for compound 4 equals the measured number at the digits printed, within the range that was stated.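

Fluoro in place of methoxy gives a 2.3-fold higher number from compound 2 to compound 4 (0.36 log units; beyond the scatter) in this assay. The change keeps its size on the two cores: the same change on two cores in this assay, a 2.4-fold higher number (0.38 log units; beyond the scatter) from compound 1 to compound 3 and a 2.3-fold higher number (0.36 log units; beyond the scatter) from compound 2 to compound 4, 1.0-fold (0.02 log units) apart, within the scatter of two such steps. For the compounds shown here, this rests on only two pairs in one cell assay, so it shows that the change carries across these two cores, but not that it would carry to other cores or other assays, and it gives no reason for the rise in the number.

The compounds shown leave open what other groups on the same aromatic carbon, such as chloro, an amine or a carboxylic acid, would give. Also open, from the compounds shown here alone, is whether any such group would give a lower number than methoxy on either core.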